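The compounds below may be only part of what the source reports. "The series", "measured", "known", "first", "only" and "open" are said of these compounds alone.

In a functional assay on SMMC-7721 cells (Homo sapiens) for cytotoxicity, read by MTT assay, with a stated time of 72 h (a lower number here means a stronger inhibitor, a higher number a weaker inhibitor), compound 1 `O=C1C(=Cc2ccc(O)cc2)C(=O)N(c2ccc(Cl)cc2)N1c1ccc(Cl)cc1` gives 20600 nM with hydroxy on one aromatic ring of the shared core. Compound 3 `O=C1C(=Cc2ccc(F)cc2)C(=O)N(c2ccc(Cl)cc2)N1c1ccc(Cl)cc1` carries fluoro there and gives 23300 nM in the same assay. That places compound 3 level with compound 1, the two being within the scatter of each other. Compound 2 `CN(C)c1ccc(C=C2C(=O)N(c3ccc(Cl)cc3)N(c3ccc(Cl)cc3)C2=O)cc1` carries dimethylamino, and its > 128000 nM is a limit of the assay, not a number.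

Compound 4 `O=C1C(=Cc2ccc(Cl)cc2)C(=O)N(c2ccc(Cl)cc2)N1c1ccc(Cl)cc1` has not been measured yet. It differs from compound 3 by chloro in place of fluoro on an aromatic carbon and has chloro in place of fluoro on an aromatic carbon. Among the measured compounds shown here, two measured steps bear on this change. Fluoro for hydroxy gave a 1.1-fold higher number from compound 1 to compound 3 (0.05 log units; within the scatter) while dimethylamino for hydroxy gave an at least 6.2-fold higher number from compound 1 to compound 2 (0.79 log units; beyond the scatter) and only the dimethylamino step left the scatter. A swap of one halogen for another looks closer to the fluoro step, so no step beyond the scatter is expected in this assay here. The estimated step is a 1.2-fold lower number from compound 3 to compound 4 (0.07 log units; within the scatter) and would leave the two compounds close together. For compound 4 the expected value is 20000 nM with an estimated range from 9000 nM to 45000 nM in this assay.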

Compound 4, half-maximal inhibitory concentration: 30900 nM
Compound 4: the middle estimate sits 1.5-fold (0.19 log units) below what was measured; the range from low to high includes it.
By their numbers in this assay, from the lowest: compounds 1, 3 and 4 (each within the scatter of the next). At a limit, above all of these: compound 2.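

In this assay, the change from 4-fluorophenyl to 4-chlorophenyl gives a 1.3-fold higher number from compound 3 to compound 4 (0.12 log units; within the scatter), so the two halogens cannot be told apart at this position. Chloro also cannot be told apart from hydroxy, with a 1.5-fold higher number from compound 1 to compound 4 (0.18 log units; within the scatter), which means that hydroxy, fluoro and chloro now form one group of three on this aromatic carbon. Dimethylamino alone stands apart, with an at least 4.1-fold lower number from compound 2 to compound 4 (0.61 log units; beyond the scatter), and what compound 2 carries is a limit of the assay, not a number: the limit of > 128000 nM in this assay, at which 1 of the 4 values shown sits.

The compounds shown leave open whether a simple amino group or a methoxy group at this position would fall with dimethylamino or with the other three. They also leave open whether a larger halogen such as bromo, or a trifluoromethyl group, would stay within this group of three.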